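A few compounds are considered here, and "the series" means these few. Any claim that something is new, unique, unknown or untested is made for them only; others in the source may bear on it.

Measured so far:
- compound 1, `O=C1CS/C(=N/N=C/c2c[nH]c3ccccc23)N1c1cccc2ccccc12`: 25700 nM
- compound 2, `Cc1ccc(N2C(=O)CS/C2=N/N=C/c2c[nH]c3ccc(Br)cc23)cc1`: 98500 nM

Of the compounds shown here, two share a core and have been tested in a functional assay on OVCAR-3 cells (Homo sapiens) for inhibition, read by spectrophotometry and sulforhodamine B assay, with a stated time of 48 h; on this read-out lower numbers stand for stronger inhibition of growth and higher numbers for weaker inhibition of growth. Compound 1 gives 25700 nM, while compound 2 gives 98500 nM, the higher of the two numbers, which means weaker inhibition of growth; the gap between them is beyond the usual scatter. Going by the values given here, compound 1 and compound 2 differ in two places at once, so no single structural step joins them.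

Compound 3, `Cc1ccc(N2C(=O)CS/C2=N/N=C/c2c[nH]c3ccccc23)cc1`, has not yet been measured. It is made from compound 2 by one change: hydrogen in place of bromo on an aromatic carbon. Removing bromo has not been tried elsewhere in this set, so the size and direction of the step are open. Compound 3 is expected to land near compound 2 in this assay, with a step of a 1.6-fold lower number from compound 2 to compound 3 (0.22 log units; within the scatter) that may well stay within the scatter, and no more than a modest improvement is anticipated. The estimate for compound 3 is 60000 nM, with a range from 20000 nM to 200000 nM.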

Compound 3, concentration for 50% growth inhibition: > 100000 nM
Compound 3: a limit, no number (the forecaster's own chance of this, stated with the estimate: 20%); at least 1.6-fold (0.22 log units) between middle value and limit.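

In this assay compound 3 sits at a limit of the assay, > 100000 nM, which is a limit and not a number. Putting hydrogen in place of bromo, on an aromatic carbon of the six-membered ring of carbon only in the fused system, gives an at least 1.0-fold higher number from compound 2 to compound 3 (0.00 log units; that floor lies within the scatter), so this step has a floor but no measured size, and that floor does not separate the two compounds. Compound 1 and compound 2 differ in two places at once and could not isolate this position, whereas this single change shows that taking bromo away here brings no visible gain in growth inhibition, though any real loss stays hidden behind the top of the measuring range: the limit of > 100000 nM in this assay, at which 1 of the 3 values shown sits.

The compounds shown leave open how a different group at this place, such as an amine, a methoxy group or a carboxylic acid, would read, and whether any of them would give a clearly lower number. They also leave open whether bromo at this place would shift the number in the same way on compound 1.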